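The source may hold more compounds than are shown below. What is called first, only, known or untested is meant among the compounds shown, and "the series" means these compounds.

Compound 1 `CCNC(=O)NC1=CS(=O)(=O)O[C@@]12[C@@H](CO[Si](C)(C)C(C)(C)C)O[C@@H](n1cc(C)c(=O)n(C)c1=O)[C@@H]2O[Si](C)(C)C(C)(C)C`: 10000 nM
Compound 2 `Cc1cn([C@@H]2O[C@H](CO[Si](C)(C)C(C)(C)C)[C@@]3(OS(=O)(=O)C=C3NCCC(=O)OCc3ccccc3)[C@H]2O[Si](C)(C)C(C)(C)C)c(=O)n(C)c1=O`: 200000 nM
Compound 3 `COC(=O)CC(=O)NC1=CS(=O)(=O)O[C@@]12[C@@H](CO[Si](C)(C)C(C)(C)C)O[C@@H](n1cc(C)c(=O)n(C)c1=O)[C@@H]2O[Si](C)(C)C(C)(C)C`: 29000 nM

These three compounds share one core and differ only in the group attached to an amine nitrogen on that core. All were tested in a functional assay on HEL cells (Homo sapiens); on this read-out lower numbers stand for higher toxicity in this test and higher numbers for lower toxicity in this test. Among the three numbers, compound 1 gives the lowest and is therefore the most toxic in this set; compound 3 stands nearest, with a 2.9-fold higher number from compound 1 to compound 3 (0.46 log units; beyond the scatter), and compound 2 lies furthest away, with a 20-fold higher number from compound 1 to compound 2 (1.30 log units; beyond the scatter).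

Compound 4 `Cc1cn([C@@H]2O[C@H](CO[Si](C)(C)C(C)(C)C)[C@@]3(OS(=O)(=O)C=C3NCCC(=O)O)[C@H]2O[Si](C)(C)C(C)(C)C)c(=O)n(C)c1=O` has not yet been measured. It differs from compound 1 in one place: 2-carboxyethyl in place of ethylcarbamoyl on an amine nitrogen. Among the compounds with values here, the chain that enters resembles the one in compound 2, except that the 2-(benzyloxycarbonyl)ethyl group of compound 2 is here a 2-carboxyethyl group. The step bearing most directly on this change is a 20-fold higher number from compound 1 to compound 2 (1.30 log units; beyond the scatter), which was large; the related step of a 2.9-fold higher number from compound 1 to compound 3 (0.46 log units; beyond the scatter) was modest, and between those two alternatives stands a 6.9-fold lower number from compound 2 to compound 3 (0.84 log units; beyond the scatter). Both replacements of the ethylcarbamoyl group raised the number, the chain of compound 2 by far the most. A large rise toward lower toxicity in this assay is therefore expected: a 15-fold higher number from compound 1 to compound 4 (1.18 log units; beyond the scatter). The estimate for compound 4 is 150000 nM, with a range from 40000 nM to 500000 nM.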

Compound 4, half-maximal cytotoxic concentration: 34000 nM
Compound 4: the middle estimate sits 4.4-fold (0.64 log units) above what was measured, outside the stated range (below it).
By their numbers in this assay, from the lowest: compound 1; then compounds 3 and 4 (each within the scatter of the next); then compound 2.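

In this assay the benzyl group on the oxygen proves to matter, since hydrogen in its place gives a 5.9-fold lower number from compound 2 to compound 4 (0.77 log units; beyond the scatter) and the high number of compound 2 is not kept by the free acid. Against the ethylcarbamoyl group, the 2-carboxyethyl group still gives a 3.4-fold higher number from compound 1 to compound 4 (0.53 log units; beyond the scatter) with a smaller rise than compound 2 showed, and it sits level with the chain of compound 3, as a 1.2-fold higher number from compound 3 to compound 4 (0.07 log units; within the scatter) shows. At this amine nitrogen, then, compound 1 remains the lowest of the four, and how far the number moves depends on what ends the new chain, not merely on the loss of the ethylcarbamoyl group.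

No measurement at hand explains why the benzyl group makes this difference. The compounds shown also leave open whether a longer chain ending in a carboxylic acid, or a chain ending in an amine, on the same nitrogen would stay close to compound 4 or climb towards compound 2.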